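The source may hold more compounds than are shown below. What is called first, only, known or untested is meant among the compounds shown, and "the series" means these compounds.

Compound 3 `O=C(CCCCC1CCSS1)NCc1cn(CCCCOc2ccc3ccc(=O)oc3c2)nn1` gives 69.8% in a functional assay on PC-12 cells (Rattus norvegicus) for cytotoxicity, read by MTT assay, with stated times of 3 h and 2 h, tested at 20 uM (on this read-out higher numbers stand for a stronger effect at the one concentration tested and lower numbers for a weaker effect), the highest of the three numbers in hand; compound 1 `CC(=O)c1cc2ccc(OCCCn3cc(CNC(=O)CCCCC4CCSS4)nn3)cc2oc1=O` gives 39.8% and compound 2 `O=C(CCCCC1CCSS1)NCc1cn(CCCOc2ccc3cc(-c4ccccc4)c(=O)oc3c2)nn1` gives 27.2%, each beyond the scatter below compound 3. Compound 4 `COc1ccc(-c2cc3ccc(OCCCCn4cc(CNC(=O)CCCCC5CCSS5)nn4)cc3oc2=O)cc1` differs from compound 3 by 4-methoxyphenyl in place of hydrogen on an aromatic carbon. Within the data shown here, the single measured step that bears on this change also brings an aromatic ring onto the shared core: a number 12.6 percentage points lower from compound 1 to compound 2 (beyond the scatter). Compound 2, which carries that phenyl, is also the lowest of the three. A downward step of similar or somewhat larger size is therefore expected, a number 19.8 percentage points lower from compound 3 to compound 4 (beyond the scatter). Compound 4 is estimated at 50%, with a range from 30% to 70%.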

Compound 4, a percentage reported as activity, at one concentration (the size of the read-out at that concentration, not a potency): 52.3%
Beside the measured number, compound 4's estimate is 2.3 percentage points below it; low and high end bracket the measured number.
By their numbers in this assay, from the lowest: compound 2; then compound 1; then compound 4; then compound 3.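

Hydrogen on this aromatic carbon is now compared directly with an aryl group: in this assay, 4-methoxyphenyl gives a number 17.5 percentage points lower from compound 3 to compound 4 (beyond the scatter). Both steps at this carbon that bring in an aromatic ring go downward, the other being a number 12.6 percentage points lower from compound 1 to compound 2 (beyond the scatter), and neither compound in these steps goes against that direction. No measurement in hand accounts for either drop.

Open, as far as these compounds go, is whether a small group such as methyl, or an amine or carboxylic acid on the added phenyl ring, would follow the same direction. Also open, from the compounds shown here alone, is whether unsubstituted phenyl differs from 4-methoxyphenyl here.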